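Chain shortening on a quinoline hydroxamate series

This account rests on a few compounds, and the source may have more. Where it says the series, first, only, none or still open, it means among the compounds named here.

Compound 1 `COc1cc2c(Oc3ccc(NC(=O)c4nn(-c5ccccc5C)cc(C)c4=O)cc3)ccnc2cc1OCCCC(=O)NO` gives 4460 nM in a functional assay on A549 cells (Homo sapiens) for inhibition, read by MTT assay, with a stated time of 72 h; a lower number here means a stronger inhibitor, a higher number a weaker inhibitor. Compound 2 `COc1cc2c(Oc3ccc(NC(=O)c4nn(-c5ccccc5C)cc(C)c4=O)cc3)ccnc2cc1OCC(=O)NO` carries hydroxycarbamoyl in place of 2-(hydroxycarbamoyl)ethyl on a saturated chain carbon bound to an oxygen on an aromatic ring, and this gave a 1.3-fold higher number from compound 1 to compound 2 (0.13 log units; within the scatter). In this assay compound 2 gives 5980 nM. Compound 3 `COc1cc2c(Oc3ccc(NC(=O)c4nn(-c5ccccc5F)cc(C)c4=O)cc3F)ccnc2cc1OCCCCCC(=O)NO` has a different core; how that core differs from the core of compound 1 is not broken down here. In this assay compound 3 gives 1320 nM, the lowest of the three numbers. Compound 4 `COc1cc2c(Oc3ccc(NC(=O)c4nn(-c5ccccc5F)cc(C)c4=O)cc3F)ccnc2cc1OCCCC(=O)NO` is not yet measured. It shows the same kind of change as compound 1 to compound 2, namely (hydroxycarbamoyl in place of 2-(hydroxycarbamoyl)ethyl on a saturated chain carbon, three bonds along the chain from an oxygen on an aromatic ring), so the place differs in lying three bonds along the chain from the oxygen rather than bound to it. Because the earlier step was a 1.3-fold higher number from compound 1 to compound 2 (0.13 log units; within the scatter), the step from compound 3 to compound 4 is expected to be about a 1.4-fold higher number from compound 3 to compound 4 (0.13 log units; within the scatter). Compound 4 is therefore estimated at 1800 nM, between 900 nM and 3600 nM.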

Compound 4, half-maximal inhibitory concentration: 1370 nM
Compound 4: the middle estimate sits 1.3-fold (0.12 log units) above what was measured; the measured number falls inside the stated range.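

Putting hydroxycarbamoyl in place of 2-(hydroxycarbamoyl)ethyl on the core of compound 3 gave a 1.0-fold higher number from compound 3 to compound 4 (0.02 log units; within the scatter) in this assay. Set beside the earlier step, the two cores agree: the same change on two cores in this assay, a 1.3-fold higher number (0.13 log units; within the scatter) from compound 1 to compound 2 and a 1.0-fold higher number (0.02 log units; within the scatter) from compound 3 to compound 4, 1.3-fold (0.11 log units) apart, within the scatter of two such steps. On these two cores, then, this chain shortening carried across with no step beyond the scatter, but two pairs do not show that it would do so on any other core or in any other assay.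

The compounds shown leave open how the 5-(hydroxycarbamoyl)pentyl chain would read on the core of compound 1, and how the (hydroxycarbamoyl)methyl chain would read on the core of compound 3. They also leave open whether a carboxylic acid in place of the hydroxycarbamoyl end would read the same on either core.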